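The source may report more compounds than this note shows. Statements on the series, on what has been measured and on what is new or still open speak of the compounds shown alone.

Compound 1 `CC(C)(N)CC(=O)N[C@@H]1CCc2ccccc2N(Cc2ccc(-c3ccccc3C(=O)O)cc2)C1=O`: 2500 nM in a functional assay (Pituitary gland cell) with Rattus norvegicus as the target; a lower number here means that less compound is needed, a higher number that more compound is needed for the effect.
Compound 2 `CC(C)(N)CC(=O)N[C@@H]1CCc2ccccc2N(Cc2ccc(-c3ccccc3-c3nc[nH]n3)cc2)C1=O`: 90 nM in this assay.

Going by the values given here, compound 2 stands lowest of the two numbers; the only other compound measured, compound 1, needs more. Compound 3 `CC(C)(N)CC(=O)N[C@@H]1CCc2ccccc2N(Cc2ccc(-c3cscc3-c3nn[nH]n3)cc2)C1=O` has not yet been measured; it differs from compound 2 by 4-(2H-tetrazol-5-yl)thiophen-3-yl in place of 2-(1H-1,2,4-triazol-3-yl)phenyl on an aromatic carbon. Among the compounds with values here, the one measured step, a 28-fold lower number from compound 1 to compound 2 (1.44 log units; beyond the scatter), concerns the same place, where a five-membered aromatic ring with three hetero atoms replaced carboxy. Compound 3 keeps a five-membered aromatic ring with four hetero atoms there, so the step is expected to be a 1.7-fold higher number from compound 2 to compound 3 (0.22 log units; within the scatter), smaller than that earlier step. Compound 3 is therefore estimated at 150 nM, within 30 nM to 800 nM.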

Compound 3, half-maximal effective concentration: 150 nM
Estimate against measurement, compound 3: no gap at the digits printed; the range from low to high includes it.
By their numbers in this assay, from the lowest: compounds 2 and 3 (each within the scatter of the next); then compound 1.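

In this assay, replacing both rings at once, with 4-(2H-tetrazol-5-yl)thiophen-3-yl taking the place of 2-(1H-1,2,4-triazol-3-yl)phenyl, gives a 1.7-fold higher number from compound 2 to compound 3 (0.22 log units; within the scatter), so this position accepts either group without a readable difference. The advantage over the carboxylic acid group also remains, with 4-(2H-tetrazol-5-yl)thiophen-3-yl in place of 2-carboxyphenyl giving a 17-fold lower number from compound 1 to compound 3 (1.22 log units; beyond the scatter). Nothing available explains why these two groups give such similar numbers.

From the compounds shown here alone, because both rings changed together, the separate effect of each remains open. So does how a sulfonamide attached to the phenyl ring would compare at this position.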